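Sulfonamide for Carboxamide on the Shared Aryl Core

This account rests on a few compounds, and the source may have more. Where it says the series, first, only, none or still open, it means among the compounds named here.

Compound 3, `CCN(CC)C(=O)c1ccc(S(=O)(=O)N2CCC[C@@H](C(=O)N3CCC(F)(F)CC3)C2)cc1`, gives 240 nM in a functional assay on BXPC-3 cells (Homo sapiens) for inhibition, read by MTT assay, with a stated time of 7 days (a lower number here means a stronger inhibitor, a higher number a weaker inhibitor), the lowest of the three numbers recorded. Compound 2, `CCN(CC)S(=O)(=O)c1ccc(S(=O)(=O)N2CCC[C@@H](C(=O)N3CCOCC3)C2)cc1`, gives 790 nM, and compound 1, `CCN(CC)S(=O)(=O)c1ccc(S(=O)(=O)N2CCC[C@@H](C(=O)N3CCC(OC)CC3)C2)cc1`, gives 1420 nM; both gaps to compound 3 lie beyond the scatter. Within the data shown here, the only single-point step measured so far, a 1.8-fold lower number from compound 1 to compound 2 (0.25 log units; within the scatter), concerns the amide ring and lies within the scatter. Compound 4, `CCN(CC)S(=O)(=O)c1ccc(S(=O)(=O)N2CCC[C@@H](C(=O)N3CCC(F)(F)CC3)C2)cc1`, differs from compound 3 by diethylsulfamoyl in place of diethylcarbamoyl on an aromatic carbon. Among the measured compounds shown here, no measured pair isolates this change: compounds 1 and 2 carry the diethylsulfamoyl group but also other amide rings, so their higher numbers cannot be set against compound 3 cleanly. For the measured compounds named here, still, the only two compounds bearing that group sit well above compound 3, and the amide-ring change measured between them was small. The step of a 2.9-fold higher number from compound 3 to compound 4 (0.46 log units; beyond the scatter) is therefore expected to run toward a higher number, probably beyond the scatter, though loosely bounded. Compound 4 is estimated at 700 nM, within a range of 250 nM to 2000 nM.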

Compound 4, half-maximal inhibitory concentration: 120 nM
Compound 4: the middle estimate sits 5.8-fold (0.77 log units) above what was measured, outside the stated range (below it).
By their numbers in this assay, from the lowest: compounds 4 and 3 (each within the scatter of the next); then compounds 2 and 1 (each within the scatter of the next).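

With the 4,4-difluoropiperidin-1-yl group held fixed, diethylsulfamoyl in place of diethylcarbamoyl on the aromatic carbon gives a 2.0-fold lower number from compound 3 to compound 4 (0.30 log units; within the scatter) in this assay, so the two groups are not told apart at this position. Diethylsulfamoyl is common to both partners in a 6.6-fold lower number from compound 2 to compound 4 (0.82 log units; beyond the scatter) and in a 12-fold lower number from compound 1 to compound 4 (1.07 log units; beyond the scatter), and each of these steps changes only the ring on the carbonyl carbon. The higher numbers of compound 1 and compound 2 therefore go with their morpholin-4-yl and 4-methoxypiperidin-1-yl rings, not with the diethylsulfamoyl group.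

No measurement at hand accounts for these steps. As far as these compounds go, it remains open how this aromatic carbon responds to a group of another kind, such as an amine or a carboxylic acid, or to chains longer than ethyl on the sulfonamide nitrogen.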